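The compounds below may be only part of what the source reports. "The series", "measured", "known", "first", "only" and "open" are said of these compounds alone.

Compounds measured in a functional assay on U-87MG ATCC cells for antiproliferative activity against U-87 MG (Homo sapiens), read by MTT assay, with a stated time of 48 h, tested at 100 uM; on this read-out lower numbers stand for a stronger effect and higher numbers for a weaker effect at the one concentration tested:
- compound 1, `COc1ccc(-c2nc(SCC(=O)c3sc(-c4ccccc4)nc3C)nc(N)c2C#N)cc1`: 17.2%
- compound 2, `COc1ccc(-c2nc(C)c(C(=O)CSc3nc(N)c(C#N)c(-c4ccc(Cl)cc4)n3)s2)cc1`: 3.9%
- compound 3, `Cc1nc(-c2ccccc2)sc1C(=O)CSc1nc(N)c(C#N)c(-c2ccc(Cl)cc2)n1`: 17.1%

On these numbers compound 3 stands second highest of the three. Its nearest neighbour is compound 1, which in this assay gives 17.2%; the two lie within the scatter of each other, and the step of a number 0.1 percentage points lower from compound 1 to compound 3 (within the scatter) bears this out. Compound 2 is furthest away, and the step of a number 13.2 percentage points higher from compound 2 to compound 3 (beyond the scatter) is beyond the scatter.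

Compound 4, `Cc1nc(-c2ccc(Cl)cc2)sc1C(=O)CSc1nc(N)c(C#N)c(-c2ccc(Cl)cc2)n1`, differs from compound 3 in one place: chloro in place of hydrogen on an aromatic carbon

For the measured compounds named here, two measured steps bear on this change. The step of a number 0.1 percentage points lower from compound 1 to compound 3 (within the scatter) shows a chloro in place of methoxy on the other aromatic ring making no difference beyond the scatter. The step of a number 13.2 percentage points higher from compound 2 to compound 3 (beyond the scatter) shows that a methoxy on the ring now being changed gave a lower number than hydrogen. A chloro entering the same position might recover part of that, but there is no measured chloro on this ring, so the direction rests on one step. Compound 4 is therefore expected to give a modestly lower number than compound 3, a step of a number 6.1 percentage points lower from compound 3 to compound 4 (within the scatter), and compound 4 is estimated at 11% with a range of 2% to 22%.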

Compound 4, a percentage reported as activity, at one concentration (the size of the read-out at that concentration, not a potency): 1.65%
Compound 4: the middle estimate sits 9.4 percentage points above what was measured; measured number outside the range, below it.
By their numbers in this assay, from the lowest: compounds 4 and 2 (each within the scatter of the next); then compounds 3 and 1 (each within the scatter of the next).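

In this assay, the change from phenyl to 4-chlorophenyl gives a number 15.5 percentage points lower from compound 3 to compound 4 (beyond the scatter), so at this position, para to a large group, a chloro goes with a lower number, as the methoxy of compound 2 does. The earlier compounds had shown chloro and methoxy only on the other aromatic ring; exchanging the two at this position also leaves the number within the scatter, with a number 2.3 percentage points lower from compound 2 to compound 4 (within the scatter). The exchange reads alike on both cores: the same change on two cores in this assay, a number 0.1 percentage points lower (within the scatter) from compound 1 to compound 3 and a number 2.3 percentage points lower (within the scatter) from compound 2 to compound 4, 2.2 percentage points apart, within the scatter of two such steps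

The compounds shown leave open whether other groups at this position, such as an amine or a carboxylic acid, would also go with a low number. Readings at the one concentration also give no potency for compound 2 or compound 4.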